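From Acetyl to Isopropyl on the Aromatic Ring

A few compounds are considered here, and "the series" means these few. Any claim that something is new, unique, unknown or untested is made for them only; others in the source may bear on it.

Among the compounds with values here, in a functional assay (mast cells) for inhibition, with Rattus norvegicus as the target (a higher number here means that more compound is needed for the effect, a lower number that less compound is needed), compound 2 `CC(=O)c1ccc(N/N=C2\CCC(C)n3c2ncc(C(=O)O)c3=O)cc1` holds the lower of the two numbers so far, at 8100 nM. Within the data shown here, its only neighbour, compound 1 `COc1ccc(N/N=C2\CCC(C)n3c2ncc(C(=O)O)c3=O)cc1`, gives 128000 nM. Compound 3 `CC(C)c1ccc(N/N=C2\CCC(C)n3c2ncc(C(=O)O)c3=O)cc1` has not yet been measured and carries isopropyl in place of acetyl on an aromatic carbon. Among the measured compounds shown here, one measured step bears on this change: a 16-fold lower number from compound 1 to compound 2 (1.20 log units; beyond the scatter), a large step beyond the scatter, with acetyl in place of methoxy at the same place. For the measured compounds named here, no measured compound carries isopropyl, so the size of the change remains uncertain. Taking that single step as a guide, a move back towards a higher number is expected, covering only part of its size. The estimated change is a 4.3-fold higher number from compound 2 to compound 3 (0.64 log units; beyond the scatter). For compound 3 the expected value is 35000 nM, with an estimated range from 9000 nM to 130000 nM.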

Compound 3, half-maximal effective concentration: 1200 nM
Estimate against measurement, compound 3: 29-fold (1.46 log units) above; measured number below the stated range.
By their numbers in this assay, from the lowest: compound 3; then compound 2; then compound 1.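

In this assay, isopropyl, which has no hydrogen-bond acceptor, takes the number further down than acetyl, which has one, giving a 6.8-fold lower number from compound 2 to compound 3 (0.83 log units; beyond the scatter); at this place, para to a large group, the acceptor of acetyl is therefore not needed for the lower number. Across the three compounds, the change of this single group from methoxy to isopropyl gives a 110-fold lower number from compound 1 to compound 3 (2.03 log units; beyond the scatter), so this place alone moves the number over a wide range while the shared core stays the same. Nothing measured here accounts for the order of the three groups.

Within the data shown here, with only three groups at one place, it remains open whether the number falls further with a longer chain such as tert-butyl. As far as these compounds go, it is equally open how an amine or a chlorine atom would behave at this place.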